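The source may hold more compounds than are shown below. What is called first, only, known or untested is meant among the compounds shown, and "the series" means these compounds.

Going by the values given here, compound 2 `CC(=O)c1cccc(NC(=O)N[C@H](C)c2ccccc2)c1` stands lowest of the two numbers recorded in an ADME assay on the whole organism with Oryza sativa as the target, tested at 10 uM; on this read-out lower numbers stand for a stronger effect and higher numbers for a weaker effect at the one concentration tested: compound 2 gives 73%, whereas compound 1 `CCOC(=O)c1cccc(NC(=O)N[C@H](C)c2ccccc2)c1` gives 88%, the only measured step being a number 15 percentage points lower from compound 1 to compound 2 (beyond the scatter). Compound 3 `C[C@@H](NC(=O)Nc1cccc(Cl)c1)c1ccccc1` has not yet been measured; it differs from compound 2 by chloro in place of acetyl on an aromatic carbon. Among the compounds with values here, no measured step involves a chloro group, so the modest shift from compound 1 to compound 2 concerned a different exchange and offers little direct guidance. For compound 3 a step of a number 2 percentage points higher from compound 2 to compound 3 (within the scatter) is expected, which lies within the scatter. Compound 3 is therefore estimated at 75%, in a range from 55% to 92%.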

Compound 3, a percentage reported as activity, at one concentration (the size of the read-out at that concentration, not a potency): 83%
Compound 3: the middle estimate sits 8 percentage points below what was measured, within the range that was stated.
By their numbers in this assay, from the lowest: compounds 2, 3 and 1 (each within the scatter of the next, the first and the last beyond it).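

At this aromatic carbon, meta to a large group, chloro is the first group shown without a carbonyl, and in this assay the comparison gives a number 10 percentage points higher from compound 2 to compound 3 (within the scatter) and a number 5 percentage points lower from compound 1 to compound 3 (within the scatter). A single chlorine atom can therefore take the place of either acetyl or ethoxycarbonyl without leaving the scatter, so a carbonyl on this carbon is not needed for a number in this range. Nothing measured here explains these numbers. On these data alone, whether an amine or a carboxylic acid on this same carbon would give a number beyond the scatter of all three compounds remains open.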